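Pyridin-2-yl for Methyl on a Pyrazolopyridinone Core

This account rests on a few compounds, and the source may have more. Where it says the series, first, only, none or still open, it means among the compounds named here.

The measured compounds:
- compound 1, `Cc1cc2c(c(N)nn2C)c(N2CCCCC2)n1`: 17%
- compound 2, `Cc1cc2nn(-c3ccccc3)c(N)c2c(=O)[nH]1`: 5%

The read-out throughout is an assay on isolated protein for inhibition of MAP kinase-activated protein kinase 5 (Homo sapiens), read by mobility shift assay, tested at 30 uM; a higher number here means more inhibition at the concentration tested (going by the name of the read-out), a lower number less inhibition. Compound 1, `Cc1cc2c(c(N)nn2C)c(N2CCCCC2)n1`, gives 17% in this assay. Compound 2, `Cc1cc2nn(-c3ccccc3)c(N)c2c(=O)[nH]1`, gives 5% in this assay, the lower of the two numbers, and the gap to compound 1 lies beyond the usual scatter of such measurements.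

Compound 3, `Nc1c2c(=O)[nH]c(-c3ccccn3)cc2nn1-c1ccccc1`, has not yet been measured. It differs from compound 2 in a single place: pyridin-2-yl in place of methyl on an aromatic carbon. For the measured compounds named here, no pair of measured compounds shows this change, so its effect is unknown from the data at hand.

Compound 2 sits near the bottom of the scale, so there is little room downward. In the absence of any measured step of this kind, the step from compound 2 to compound 3 is expected to be small, a number 5 percentage points higher from compound 2 to compound 3 (within the scatter), most likely not beyond the scatter. Compound 3 is therefore estimated at 10%, within a range from 0% to 30%.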

Compound 3, a percentage reported as inhibition, at one concentration (the size of the read-out at that concentration, not a potency): 2%
Estimate against measurement, compound 3: 8 percentage points above; the range from low to high includes it.
By their numbers in this assay, from the lowest: compounds 3 and 2 (each within the scatter of the next); then compound 1.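

Placing pyridin-2-yl instead of methyl on this aromatic carbon, next to the ring nitrogen, gives in this assay a number 3 percentage points lower from compound 2 to compound 3 (within the scatter) and is the only measured change at this position. The carbon therefore carries either a methyl or a pyridin-2-yl without any shift beyond the scatter, and the added aromatic ring, with its hydrogen-bond acceptor, brings no measurable gain in inhibition at the concentration tested. Because both compounds sit near the bottom of the scale, this step cannot show whether the swap is neutral or harmful, and no measurement at hand explains the outcome.

As far as these compounds go, whether a different group on this carbon, such as an amine, a carboxylic acid or a longer alkyl chain, would raise the read-out remains open, as does the effect of replacing the phenyl on the ring nitrogen. Compound 1 differs from compound 2 in more than one place, so the structural source of the gap between their values also remains unresolved.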